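A few compounds are considered here, and "the series" means these few. Any claim that something is new, unique, unknown or untested is made for them only; others in the source may bear on it.

Among the compounds with values here, compound 1, with the structure `Nc1cccc(-c2cccc(NC(=O)C(Cl)Cl)c2)c1`, is the only member of this small set to give a definite number in a functional assay on KB 3-1 cells (Homo sapiens) for cytotoxicity, read by MTT assay, with a stated time of 68 h; on this read-out higher numbers stand for weaker inhibition and lower numbers for stronger inhibition: compound 1 gives 26100 nM. Compound 2, `COc1ccccc1-c1cc(NC(=O)C(Cl)Cl)cc(-c2ccccc2OC)c1`, reaches only a limit of the assay, and in this assay compound 2 gives > 30000 nM. Compound 3, `COc1ccc(-c2cc(NC(=O)C(Cl)Cl)cc(-c3ccc(OC)cc3)c2)cc1`, likewise stops at a limit, and in this assay compound 3 gives > 30000 nM. Thus the limit of > 30000 nM in this assay, at which 2 of the 3 values shown sit, marks where two of the three results stand, and compound 1 alone yields a number.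

Compound 4, `O=C(Nc1cccc(-c2ccccc2)c1)C(Cl)Cl`, is not yet measured. It differs from compound 1 in one place: hydrogen in place of amino on an aromatic carbon. Within the data shown here, no pair of measured compounds differs in a single place, so no measured step shows what such a change does. Compound 2 and compound 3 carry further changes as well, and their results show only that both sit at a limit. For this change the step expected in this assay is a 1.2-fold lower number from compound 1 to compound 4 (0.07 log units; within the scatter), a shift that would stay close to the scatter of repeated runs. The expected result for compound 4 is 22000 nM, likely between 9000 nM and 50000 nM.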

Compound 4, half-maximal inhibitory concentration: 46800 nM
Compound 4: the middle estimate sits 2.1-fold (0.33 log units) below what was measured; the measured number falls inside the stated range.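

Within the data shown here, the pair of compound 1 and compound 4 gives the first direct reading of this place: with hydrogen in place of amino on this aromatic carbon, this assay shows a 1.8-fold higher number from compound 1 to compound 4 (0.25 log units; within the scatter). A step of this size cannot be told apart from the spread of repeated measurements, so these two compounds give no sign that the amino group matters for the read-out on these cells. Nothing shown here gives a measured property that bears on this result.

From the compounds shown here alone, what a different group on this aromatic carbon would do remains open, for instance a hydroxyl group, a carboxylic acid or a longer chain ending in an amine. Whether any such group would give a step beyond the scatter cannot be told from the compounds shown.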